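This account rests on a few compounds, and the source may have more. Where it says the series, first, only, none or still open, it means among the compounds named here.

Measured so far:
- compound 1, `Cc1ccc(S/C(=C/c2c[nH]c3ccc(Cl)cc23)C(=O)c2ccc(Br)cc2)cc1`: 1000 nM
- compound 2, `Cc1ccc(S/C(=C/c2c[nH]c3ccc(Cl)cc23)C(=O)c2ccc(Cl)cc2)cc1`: 1000 nM
- compound 3, `COc1ccc(C(=O)/C(=C\c2ccc(Br)cc2)Sc2ccc(F)cc2)cc1`: > 100000 nM

Compounds 1 and 2 were tested in a functional assay on DU-145 cells (Homo sapiens) for inhibition, read by trypan blue exclusion, with a stated time of 96 h; on this read-out higher numbers stand for weaker inhibition of growth and lower numbers for stronger inhibition of growth. They differ by chloro in place of bromo on an aromatic carbon, and the step of no change at the digits printed from compound 1 to compound 2 (within the scatter). In this assay compound 3 reaches only a limit, > 100000 nM, so no number is known for it; this is the limit of > 100000 nM in this assay, at which 1 of the 3 values shown sits. How the core of compound 3 differs from the core of compound 1 is not broken down here.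

Compound 4, `COc1ccc(C(=O)/C(=C\c2ccc(Cl)cc2)Sc2ccc(F)cc2)cc1`, has not yet been measured. Going by the values given here, it differs from compound 3 by chloro in place of bromo on an aromatic carbon, which is the same change as the one from compound 1 to compound 2, at a place described in the same words. Since that earlier change left the value unchanged within the scatter, the step from compound 3 to compound 4 is expected to be small as well, and compound 4 is expected to sit at the same limit as compound 3. The expected step is a number no higher from compound 3 to compound 4 (the limit leaves the size open), resting on no change at the digits printed from compound 1 to compound 2 (within the scatter). For compound 4 the estimated value in this assay is 100000 nM, with a range from 30000 nM to 300000 nM.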

Compound 4, concentration for 50% growth inhibition: > 100000 nM
Compound 4 ended at the assay's limit; the forecaster's own chance of this, stated with the estimate: 80%; the middle value lies on the limit itself.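

No step can be read from compound 3 to compound 4, because both values are limits of the assay and not numbers: the limit of > 100000 nM in this assay, at which 2 of the 4 values shown sit.

The compounds shown leave open whether compound 3 and compound 4 differ at all in this assay, and so whether 4-bromophenyl to 4-chlorophenyl leaves the value unchanged on this core, as it did from compound 1 to compound 2.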